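Adding a small group beside a phenoxy-imidazoline

The compounds below may be only part of what the source reports. "The series", "measured", "known", "first", "only" and "open" are said of these compounds alone.

The three measured compounds share an imidazoline attached through a carbon to an aryl ether. Compound 1 `c1ccc(-c2cccc3c2OCC(C2=NCCN2)O3)cc1` and compound 2 `c1ccc(-c2ccc3c(c2)OCC(C2=NCCN2)O3)cc1` carry a fused bicyclic core bearing a phenyl group, while compound 3 `CC(Oc1ccccc1)C1=NCCN1` has an open phenoxy ether with a methyl on the linking carbon. In an assay on CHO cells for displacement of a labelled ligand from Alpha-2B adrenergic receptor (Homo sapiens) (on this read-out lower numbers stand for stronger inhibition and higher numbers for weaker inhibition), compound 1 gives 1070 nM, compound 2 gives 1660 nM, and compound 3 gives 166 nM, the lowest number of the three, with both others lying beyond the scatter above it.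

Compound 4 `CC(Oc1ccccc1/C=N/O)C1=NCCN1` differs from compound 3 by a group of 3 heavy atoms (1 carbon, 1 nitrogen, 1 oxygen; no ring) in place of a hydrogen atom, on an aromatic carbon. Among the compounds with values here, none of the measured compounds differ from one another in a single place, so no measured step tells how such an addition shifts the read-out. Because compound 3 already sits at 166 nM, the author expects the change to compound 4 to be modest, with a step of a 1.5-fold higher number from compound 3 to compound 4 (0.18 log units; within the scatter) expected to stay near or within the scatter. Compound 4 is accordingly estimated at 250 nM, with a range from 60 nM to 1000 nM.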

Compound 4, inhibition constant: 708 nM
The estimate for compound 4 lay 2.8-fold (0.45 log units) below the measured number; low and high end bracket the measured number.
By their numbers in this assay, from the lowest: compound 3; then compounds 4, 1 and 2 (each within the scatter of the next, the first and the last beyond it).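

In this assay there is a 4.3-fold higher number from compound 3 to compound 4 (0.63 log units; beyond the scatter) when the hydrogen atom on an aromatic carbon gives way to a group of 3 heavy atoms. Within the data shown here, this is the first change in the set made in a single place, and it shows that this aromatic carbon does not take the addition without a loss in this read-out: the step lies beyond the scatter. No measurement at hand accounts for the shift.

From the compounds shown here alone, whether a smaller group, such as a methyl, a methoxy or a chlorine atom, on this same carbon would move the number as far remains open. So does what the same group of 3 heavy atoms would do on another carbon of the ring.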